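Benzyl for 4-hydroxycyclohexyl: a step off a detection limit

The compounds below may be only part of what the source reports. "The series", "measured", "known", "first", "only" and "open" are said of these compounds alone.

Measured so far:
- compound 1 `O=C(NCCNS(=O)(=O)c1cc(-c2ccccc2Oc2ccc(O)c(O)c2)cs1)Nc1cc(C(F)(F)F)cc(C(F)(F)F)c1`: 1300 nM
- compound 2 `O=C(NCCNS(=O)(=O)c1ccc(-c2ccccc2O[C@H]2CC[C@H](O)CC2)s1)Nc1cc(Cl)cc(Cl)c1`: > 20000 nM
- compound 3 `Nc1ccc(Oc2ccccc2-c2ccc(S(=O)(=O)NCCNC(=O)Nc3ccc(Cl)cc3)s2)cc1`: > 50000 nM

These three compounds share a core and differ in the group carried on the oxygen of the aromatic ring and in the aryl urea. For the measured compounds named here, in a functional assay on HL-60 cells (Homo sapiens) for inhibition, read by CCK-8 assay, with a stated time of 48 h (a lower number here means a stronger inhibitor, a higher number a weaker inhibitor), compound 1 gives 1300 nM, the only plain number among the three. For compound 2 the assay reports only a limit, > 20000 nM, so its true value is not known. For compound 3 likewise only a limit is reported, > 50000 nM. Compound 2 therefore stands at a limit, and one other value shown is also a limit of > 20000 nM in this assay, at which 1 of the 3 values shown sits (the limit of > 50000 nM in this assay, at which 1 of the 3 values shown sits).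

Compound 4 `O=C(NCCNS(=O)(=O)c1ccc(-c2ccccc2OCc2ccccc2)s1)Nc1cc(Cl)cc(Cl)c1` has not been measured. It differs from compound 2 in one place: benzyl in place of 4-hydroxycyclohexyl on an oxygen on an aromatic ring. Going by the values given here, no measured pair shows a change of this kind, so its size cannot be read from the data. Compound 1 shows that a different aromatic group on that oxygen can give a measurable number, but its urea also differs, so it does not isolate this change.

The expectation for compound 4 is a step of an at least 1.3-fold lower number from compound 2 to compound 4 (0.12 log units; that floor lies within the scatter) from the limit of compound 2, of uncertain direction and possibly none beyond the scatter. Compound 4 is estimated at 15000 nM, within 3000 nM to 60000 nM, with a real chance that only a limit is reported again.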

Compound 4, half-maximal inhibitory concentration: 11700 nM
Estimate against measurement, compound 4: 1.3-fold (0.11 log units) above; low and high end bracket the measured number.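

In this assay compound 2 is reported only as a limit. With the urea of compound 2 kept, benzyl in place of 4-hydroxycyclohexyl on an oxygen on an aromatic ring yields a plain number: compound 4 gives 11700 nM. The change amounts to an at least 1.7-fold lower number from compound 2 to compound 4 (0.23 log units; that floor lies within the scatter), and that figure is a floor, not a full size: the limit of > 20000 nM in this assay, at which 1 of the 4 values shown sits. For the compounds shown here, compound 1 has a different urea as well as a different group on that oxygen, whereas this pair offers the first comparison that isolates the group on the oxygen.

Going by these compounds, the true value of compound 2 remains unknown, and with it how far the step reaches past its floor. The compounds shown also leave open what a carboxylic acid on the benzyl ring, or a longer chain in place of benzyl on that oxygen, would give in this assay.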